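Carbamate Nucleosides at the Assay Limit: a Benzyl Step

A few compounds are considered here, and "the series" means these few. Any claim that something is new, unique, unknown or untested is made for them only; others in the source may bear on it.

Compound 1 `CCCCCC(=O)OC[C@H]1O[C@@H](n2cnc3c(N)ncnc32)[C@H](O)[C@@H]1O`: in an assay on COS-7 cells for inhibition of sodium/nucleoside cotransporter 2 (Homo sapiens), read by scintillation counting, in the presence of a further agent that is not named here (a higher number here means a weaker inhibitor, a lower number a stronger inhibitor), compound 1 gives > 100000 nM, a limit of the assay rather than a number.
Compound 2 `CNC(=O)OC[C@H]1O[C@@H](n2cnc3c(N)ncnc32)[C@H](O)[C@@H]1O`: in this assay compound 2 gives > 100000 nM, again a limit.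
Compound 3 `CCNC(=O)OC[C@H]1O[C@@H](n2cnc3c(N)ncnc32)[C@H](O)[C@@H]1O`: in this assay compound 3 gives > 100000 nM, also a limit.

Compound 3 therefore stands nowhere in particular on the numbers shown: all three values sit at the limit of > 100000 nM in this assay, at which 3 of the 3 values shown sit, and no compound can be called stronger or weaker than another. The measured steps cannot be sized either. Going from the pentyl chain to a methylamino group gives a step that the two limits leave unreadable from compound 1 to compound 2, to an ethylamino group a step that the two limits leave unreadable from compound 1 to compound 3, and lengthening the chain by one carbon gives a step that the two limits leave unreadable from compound 2 to compound 3.

Compound 4 `Nc1ncnc2c1ncn2[C@@H]1O[C@H](COC(=O)NCc2ccccc2)[C@@H](O)[C@H]1O` carries the next change on the same carbon: phenyl in place of methyl on a saturated chain carbon bound to an amide-type nitrogen. The three measured steps bear on it only in that every change around this carbamate so far has left the value at the limit; none of them shows a size or a direction. The expected step from compound 3 is therefore a number no higher from compound 3 to compound 4 (the limit leaves the size open), with the real chance that compound 4 also gives only a limit. The estimate for compound 4 in this assay is 100000 nM, expected to lie between 20000 nM and 500000 nM.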

Compound 4, half-maximal inhibitory concentration: > 100000 nM
Compound 4 ended at the assay's limit; the forecaster's own chance of this, stated with the estimate: 70%; the middle value lies on the limit itself.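

Compound 4 also gives only a limit in this assay, not a number, so its steps from compound 1, compound 2 and compound 3 cannot be read: the limit of > 100000 nM in this assay, at which 4 of the 4 values shown sit.

The compounds shown leave open how strongly any of the four inhibits, and whether any change at this carbamate moves the value at all.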